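Allyl to benzyl ether on the shared core

The source may hold more compounds than are shown below. What is called first, only, known or untested is meant among the compounds shown, and "the series" means these compounds.

In a functional assay on BV-2 cells (Mus musculus) for inhibition, read by Griess assay, with a stated time of 24 h (on this read-out lower numbers stand for stronger inhibition and higher numbers for weaker inhibition), compound 1 `C=CCc1ccc(OC)c(-c2cc(CO)on2)c1` reads > 200000 nM, which is a limit and not a number. For the measured compounds named here, compound 2 `C=CCOCc1cc(-c2cc(CC=C)ccc2OC)no1` gives 28700 nM, the only actual number so far. The next compound is compound 3 `C=CCc1ccc(OC)c(-c2cc(COCc3ccccc3)on2)c1`, with the change phenyl in place of vinyl on a saturated chain carbon bound to an oxygen on a saturated carbon, or allyloxy to benzyloxy.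

Going by the values given here, one measured step bears on this: an at least 6.9-fold lower number from compound 1 to compound 2 (0.84 log units; beyond the scatter), with allyl in place of hydrogen on an oxygen on a saturated carbon. Its size is bounded by the limit of > 200000 nM in this assay, at which 1 of the 2 values shown sits. Compound 3 keeps a substituent on that oxygen, as compound 2 does at 28700 nM, so only a small change is expected in this assay. The estimated change is a 1.4-fold lower number from compound 2 to compound 3 (0.16 log units; within the scatter), with no step beyond the scatter expected and a lower number the likelier side. For compound 3 the expected value is 20000 nM, with an estimated range of 7000 nM to 60000 nM.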

Compound 3, half-maximal inhibitory concentration: > 200000 nM
Compound 3: no number, only a limit; the forecaster's own chance of this, stated with the estimate: 10%; middle value at least 10-fold (1.00 log units) away from the limit.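

A substituent on this oxygen is not enough on its own in this assay since allyl gives an at least 6.9-fold lower number from compound 1 to compound 2 (0.84 log units; beyond the scatter) while benzyl in place of allyl gives an at least 6.9-fold higher number from compound 2 to compound 3 (0.84 log units; beyond the scatter) and so does not keep that gain. Among the three compounds only compound 2 carries a number, so in this small set the read-out turns on which group sits on the oxygen and not merely on whether one is present. Compound 3 gives > 200000 nM which is a limit and not a number, and the step from compound 1 to compound 3 cannot be read: the limit of > 200000 nM in this assay, at which 2 of the 3 values shown sit.

As far as these compounds go, how far compound 3 lies from compound 2 remains open, as does whether the loss belongs to the phenyl ring itself. A longer chain such as butyl on the same oxygen, or a chain ending in an amine, would bear on that question.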